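A Pyrazole in Place of the Thiophene Arm

The compounds below may be only part of what the source reports. "The series", "measured", "known", "first", "only" and "open" are said of these compounds alone.

Of the compounds shown here, three share an ether-linked amide core and have been measured in an assay on HEK293 cells for agonist activity at transient receptor potential cation channel subfamily M member 8 (Homo sapiens), read by fluorescence and calcium flux, with a stated time of 15 min; on this read-out lower numbers stand for an effect already at smaller amounts and higher numbers for an effect only at larger amounts of compound. Compound 1 `CCN(Cc1ccc(C)s1)C(=O)COc1ccc(C)cc1` gives 178 nM. Compound 2 `CCN(Cc1cccs1)C(=O)COc1ccc(OC)cc1` gives 120 nM, and compound 3 `CCN(Cc1cccs1)C(=O)COc1ccc2c(c1)CCCC2` gives 689 nM. Among these three numbers compound 1 holds the second highest; the gap to compound 2 lies within the usual scatter, so the two cannot be placed in any order, while the gap to compound 3 lies beyond it, with compound 3 giving the higher number.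

Compound 4 `CCN(Cc1cc[nH]n1)C(=O)COc1ccc(C)cc1` has not yet been measured. It differs from compound 1 in one place: 1H-pyrazol-3-yl in place of 5-methylthiophen-2-yl on a saturated chain carbon bound to an amide-type nitrogen. For the measured compounds named here, no pair among the measured compounds differs in this way, so the measured numbers give no direct guide to the size of the step. On what the three measured values show, a step from compound 1 to compound 4 of an 11-fold higher number from compound 1 to compound 4 (1.05 log units; beyond the scatter) is expected, toward a higher number and beyond the scatter. For compound 4 in this assay the estimate is 2000 nM, with a range from 500 nM to 8000 nM.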

Compound 4, half-maximal effective concentration: "not active" (no number reported)
The entry for compound 4 holds no number, so the estimate cannot be set against anything.
By their numbers in this assay, from the lowest: compounds 2 and 1 (each within the scatter of the next); then compound 3.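

For the compounds shown here, compound 4 is reported as not active, with no number attached, so no step from compound 1 to compound 4 can be read. The compounds shown leave open how 1H-pyrazol-3-yl in place of 5-methylthiophen-2-yl acts on this receptor. Nothing shown offers an explanation for this result.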